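The compounds below may be only part of what the source reports. "The series", "measured", "known", "first", "only" and "open" are said of these compounds alone.

Compound 2 `O=C(/C=C/c1ccc2c(c1)B(O)OC2)c1ccc(OCc2ccccc2)cc1` stands at the edge of a toxicity assay on WI-38 cells (Homo sapiens) for cytotoxicity, read by MTT assay, with a stated time of 48 h; a higher number here means a weaker inhibitor, a lower number a stronger inhibitor: there compound 2 gives > 100000 nM, a limit rather than a number (the limit of > 100000 nM in this assay, at which 1 of the 2 values shown sits). Compound 1 `O=C(/C=C/c1ccc2c(c1)B(O)OC2)c1ccc(Cl)cc1` in this assay gives 24700 nM. Among the measured compounds shown here, the single measured step, an at least 4.0-fold higher number from compound 1 to compound 2 (0.60 log units; beyond the scatter), is the only one that bears on what follows. Compound 3 `O=C(/C=C/c1ccc2c(c1)B(O)OC2)c1ccc([N+](=O)[O-])cc1` differs from compound 2 by nitro in place of benzyloxy on an aromatic carbon. Given an at least 4.0-fold higher number from compound 1 to compound 2 (0.60 log units; beyond the scatter), taking the benzyloxy away is expected to bring the number back toward that of compound 1, a modest fall in this assay, an at least 3.3-fold lower number from compound 2 to compound 3 (0.52 log units; beyond the scatter). Compound 3 is therefore estimated at 30000 nM, within 8000 nM to 110000 nM.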

Compound 3, half-maximal inhibitory concentration: 39300 nM
For compound 3 the middle estimate is 1.3-fold (0.12 log units) below the measured one; the range from low to high includes it.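

In this assay, replacing benzyloxy with nitro gives an at least 2.5-fold lower number from compound 2 to compound 3 (0.40 log units; beyond the scatter), so at this position compound 2 stands apart from a second replacement, not only from chloro. Nitro and chloro do not separate, with a 1.6-fold higher number from compound 1 to compound 3 (0.20 log units; within the scatter). Compound 2 can be read only as a limit, not a number: the limit of > 100000 nM in this assay, at which 1 of the 3 values shown sits.

On these data alone, whether an amine or a carboxylic acid on this aromatic carbon would stay level with compound 1 and compound 3 remains open. Also open, as far as these compounds go, is whether a methoxy group would behave like benzyloxy or like the groups in those two compounds.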